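This account rests on a few compounds, and the source may have more. Where it says the series, first, only, none or still open, it means among the compounds named here.

Measured compounds:
compound 1 `COC(=O)c1ccc(-c2cnc(C(=O)CCCCCCc3ccccc3)o2)nc1`, 3.1 nM
compound 2 `O=C(CCCCCCc1ccccc1)c1ncc(-c2ccc(CO)cn2)o1`, 3.2 nM

In an assay for inhibition of Fatty-acid amide hydrolase 1 (Rattus norvegicus), using a Dixon plot (a lower number here means a stronger inhibitor, a higher number a weaker inhibitor), compound 1 gives 3.1 nM and compound 2 gives 3.2 nM. Compound 2 holds the higher of the two numbers, but the step of a 1.0-fold higher number from compound 1 to compound 2 (0.01 log units; within the scatter) lies within the scatter, so the pair cannot be ordered. Compound 3 `C[S+]([O-])/C=C/c1ccc(-c2cnc(C(=O)CCCCCCc3ccccc3)o2)nc1` is not yet measured; it differs from compound 2 by a group of 5 heavy atoms (3 carbon, 1 oxygen, 1 sulfur; no ring) in place of a group of 2 heavy atoms (1 carbon, 1 oxygen; no ring), on an aromatic carbon, the new group sitting on an aromatic carbon of a six-membered aromatic ring with 1 nitrogen. For the measured compounds named here, the only measured step bearing on this position is a 1.0-fold higher number from compound 1 to compound 2 (0.01 log units; within the scatter), an exchange of groups at the same carbon that left this assay unchanged within the scatter. Going by the values given here, no measured step covers a group of this size or one containing sulfur at that place. On that basis the expected step of a 1.1-fold higher number from compound 2 to compound 3 (0.04 log units; within the scatter) is none beyond the scatter. Compound 3 is accordingly estimated at 3.5 nM, within 1.5 nM to 9 nM.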

Compound 3, inhibition constant: 3 nM
Compound 3: middle estimate off by 1.2-fold (0.07 log units), on the high side, within the range that was stated.
By their numbers in this assay, from the lowest: compounds 3, 1 and 2 (each within the scatter of the next).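

At this carbon, two atoms from the ring nitrogen, the picture now extends to a larger group containing sulfur and a double bond outside aromatic rings. In this assay the exchange for hydroxymethyl gives a 1.1-fold lower number from compound 2 to compound 3 (0.03 log units; within the scatter) and the exchange for the group of compound 1 gives a 1.0-fold lower number from compound 1 to compound 3 (0.01 log units; within the scatter). Across these three compounds, neither the rise from 2 to 5 heavy atoms in the group nor the loss of the hydrogen-bond donor of hydroxymethyl separates the numbers. Nothing on hand accounts for this insensitivity.

Still open, as far as these compounds go, is how a carboxylic acid or an amine at this carbon would read in this assay. Equally open is whether a longer chain there would move the number beyond the scatter, since no group shown so far does.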